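From Bromo to Methoxy in a Cell Toxicity Test

The compounds below may be only part of what the source reports. "The series", "measured", "known", "first", "only" and "open" are said of these compounds alone.

Measured in a toxicity assay on THP-1 cells (Homo sapiens) for cytotoxicity, read by MTT assay; a higher number here means a weaker inhibitor of growth, a lower number a stronger inhibitor of growth:
- Compound 1 `C/C(=N\Nc1nc(-c2ccc(Cl)cc2)cs1)c1sc(-c2ccccc2)nc1C`: > 100 ug/mL (a limit of the assay, not a number)
- Compound 2 `C/C(=N\Nc1nc(-c2ccc(Br)cc2)cs1)c1sc(-c2ccccc2)nc1C`: 48.9 ug/mL

Within the data shown here, compound 2 carries the only true number so far. Compound 1 stands at the limit of > 100 ug/mL in this assay, at which 1 of the 2 values shown sits.

Compound 3 `COc1ccc(-c2csc(N/N=C(\C)c3sc(-c4ccccc4)nc3C)n2)cc1` differs from compound 2 in one place: methoxy in place of bromo on an aromatic carbon. This puts methoxy in place of bromo on an aromatic carbon, para to a large group.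

Among the measured compounds shown here, only one measured step bears on this change, and it sits on the same carbon: an at least 2.0-fold lower number from compound 1 to compound 2 (0.31 log units; beyond the scatter). For the measured compounds named here, it swaps a different pair of groups, so it shows only that a change here can move the number in this assay. A small move toward a higher number is expected, and a limit reading remains possible. The estimated step is a 1.4-fold higher number from compound 2 to compound 3 (0.16 log units; within the scatter).

For compound 3 the expected value is 70 ug/mL, with an estimated range of 30 ug/mL to 150 ug/mL.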

Compound 3, concentration for 50% growth inhibition: > 100 ug/mL
Compound 3 ended at the assay's limit; the forecaster's own chance of this, stated with the estimate: 35%; at least 1.4-fold (0.15 log units) between middle value and limit.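

Replacing bromo with methoxy on this carbon gives an at least 2.0-fold higher number from compound 2 to compound 3 (0.31 log units; beyond the scatter), so the reading in this assay responds to this swap as well as to the one from chloro to bromo. Of the three groups shown at this place, only bromo gives a true number, which means the shared core alone does not set the reading. Compound 1 and compound 3 both stand at a limit of the assay, not a number, so the step between them cannot be read: the limit of > 100 ug/mL in this assay, at which 2 of the 3 values shown sit.

Going by these compounds, how far the true values of compound 1 and compound 3 lie past that limit stays open, and with it whether chloro and methoxy differ at all. Also open, on these data alone, is where an amine, a carboxylic acid or a longer chain on this carbon would fall, and whether any other group would match or pass bromo.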